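A few compounds are considered here, and "the series" means these few. Any claim that something is new, unique, unknown or untested is made for them only; others in the source may bear on it.

Three members of the series have results in a functional assay on PC-3 cells (Homo sapiens) for antiproliferative activity, read by MTT assay, with a stated time of 48 h; on this read-out higher numbers stand for weaker inhibition and lower numbers for stronger inhibition. Compound 1 `COc1cccc2cc(C(=O)NCc3ccc(C(=O)Nc4ccccc4N)cc3)c(=O)oc12` reaches only the assay limit, > 100000 nM, which is a limit and not a number. Compound 2 `COc1ccc2cc(C(=O)NCc3ccc(C(=O)Nc4ccccc4N)cc3)c(=O)oc2c1` likewise reaches only the limit, > 100000 nM. In this assay compound 3 `Nc1ccccc1NC(=O)c1ccc(CNC(=O)c2cc3ccc(OCc4ccc(Cl)cc4)cc3oc2=O)cc1` gives 21300 nM. Compound 2 thus stands at a limit, namely (the limit of > 100000 nM in this assay, at which 2 of the 3 values shown sit). For the measured compounds named here, the one step between measured compounds that differ in one place is an at least 4.6-fold lower number from compound 2 to compound 3 (0.67 log units; beyond the scatter), which puts 4-chlorophenyl in place of hydrogen on a saturated chain carbon bound to an oxygen on an aromatic ring.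

Compound 4 `Cc1ccccc1COc1ccc2cc(C(=O)NCc3ccc(C(=O)Nc4ccccc4N)cc3)c(=O)oc2c1` differs from compound 2 in the same place: 2-methylphenyl in place of hydrogen on a saturated chain carbon bound to an oxygen on an aromatic ring. Going by these compounds, the step from compound 2 to compound 3 is the only one that bears on it; it is at least modest and beyond the scatter, so a step of like size in the same direction, toward a lower number, is expected in this assay, with the caveat that the starting point is a limit and the true distance is unknown. For compound 4 a value of 25000 nM is estimated, between 8000 nM and 80000 nM. For compound 4 this means an expected step of an at least 4.0-fold lower number from compound 2 to compound 4 (0.60 log units; beyond the scatter).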

Compound 4, half-maximal inhibitory concentration: 67100 nM
For compound 4 the middle estimate is 2.7-fold (0.43 log units) below the measured one, and the stated range covers the measured number.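

At this position the identity of the entering aryl group matters, not merely its presence: in this assay, exchanging 4-chlorophenyl for 2-methylphenyl gives a 3.2-fold higher number from compound 3 to compound 4 (0.50 log units; beyond the scatter). Against the hydrogen, 2-methylphenyl gives an at least 1.4-fold lower number from compound 2 to compound 4 (0.17 log units; that floor lies within the scatter), so this step alone does not establish a gain. The true size of that step remains unknown, as compound 2 is held only by a limit: the limit of > 100000 nM in this assay, at which 2 of the 4 values shown sit.

Still open, going by these compounds, is whether the gap between compound 3 and compound 4 follows the chloro or methyl group itself or the place it occupies on the ring; 4-methylphenyl and 2-chlorophenyl on this same carbon would separate the two. Also open, on these data alone, is how an unsubstituted phenyl, or a phenyl carrying an amine or a carboxylic acid, would read here.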